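This account rests on a few compounds, and the source may have more. Where it says the series, first, only, none or still open, it means among the compounds named here.

Measured so far in a functional assay on SK-MEL-5 cells (Homo sapiens) for inhibition, read by sulforhodamine B assay, with a stated time of 48 h, tested at 10 uM; on this read-out lower numbers stand for a stronger effect and higher numbers for a weaker effect at the one concentration tested:
compound 1 `COc1cc(Cl)cc(-c2nn(-c3cccc(NC(=O)Nc4ccc(Cl)c(C(F)(F)F)c4)c3)cc2-c2ccncc2)c1`: -71.2%
compound 2 `COc1cc(Cl)cc(-c2nn(-c3cccc(NC(=O)c4cc(C(F)(F)F)cc(C(F)(F)F)c4)c3)cc2-c2ccncc2)c1`: 67.3%

Going by the values given here, compound 1 stands lowest of the two numbers in this assay, and the only other number, that of compound 2, lies higher by a gap beyond the usual scatter; the two compounds differ in more than one place, so their two values show only that compound 1 gives the far stronger effect at the single concentration tested.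

Compound 3 `COc1cc(Cl)cc(-c2nn(-c3cccc(NC(=O)Nc4ccc(Cl)c(Cl)c4)c3)cc2-c2ccncc2)c1` is not yet measured. It differs from compound 1 by a single change, (chloro in place of trifluoromethyl on an aromatic carbon), which sits on an aromatic carbon that is ortho to a chloro group and meta to a large group. The urea that compound 1 carries is kept. Among the compounds with values here, no step between measured compounds is available to calibrate this change, so the expectation rests on compound 1 alone: a step of a number 26.2 percentage points higher from compound 1 to compound 3 (beyond the scatter) is expected, small and toward the weaker side, and possibly not beyond the scatter. On that basis compound 3 is expected to give -45% in this assay, with a range from -85% to 10%.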

Compound 3, a percentage reported as activity, at one concentration (the size of the read-out at that concentration, not a potency): 3.51%
Compound 3: middle estimate off by 48.5 percentage points, on the low side; measured number inside the range.
By their numbers in this assay, from the lowest: compound 1; then compound 3; then compound 2.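

In this assay, with the urea and the rest of compound 1 kept, chloro in place of trifluoromethyl on the aromatic carbon ortho to a chloro group and meta to a large group gives a number 74.7 percentage points higher from compound 1 to compound 3 (beyond the scatter). Going by these compounds alone, this is the first one-place comparison, and it shows that this position does not tolerate the exchange without loss: going from 4-chloro-3-(trifluoromethyl)phenyl to 3,4-dichlorophenyl takes the read-out from compound 1 at -71.2% to compound 3 at 3.51%, from a negative number to a positive one. No measurement at hand bears on what lies behind the size of this step.

Within the data shown here, whether a methyl, a methoxy or a nitrile on this aromatic carbon would read closer to compound 1 or to compound 3 remains open, since only two groups have been compared at this position. As far as these compounds go, the contribution of the urea also remains open, as compound 2 carries an amide and differs from compound 1 and compound 3 in more than one place.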